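Replacing 3-methylphenoxy with chloro

This account rests on a few compounds, and the source may have more. Where it says the series, first, only, none or still open, it means among the compounds named here.

Values in a functional assay on SGC-7901 cells (Homo sapiens) for inhibition, read by MTT assay, with a stated time of 48 h; a lower number here means a stronger inhibitor, a higher number a weaker inhibitor:
Compound 1 `Cc1nnsc1CO/N=C/c1c(C)nn(C)c1Oc1ccc(I)cc1`: > 50000 nM, a limit and not a number.
Compound 2 `Cc1cccc(Oc2c(/C=N/OCc3snnc3C)c(C)nn2C)c1`: 12800 nM.

For the measured compounds named here, compound 2 holds the only true number so far, and the other result is a limit. The next structure is compound 3 `Cc1nnsc1CO/N=C/c1c(C)nn(C)c1Cl`, with chloro in place of 3-methylphenoxy on an aromatic carbon. Going by the values given here, one measured step bears on this change: an at least 3.9-fold lower number from compound 1 to compound 2 (0.59 log units; beyond the scatter), which lies beyond the scatter. That step swapped only the aromatic group on the oxygen, and this assay responded. Compound 3 loses this oxygen and its aromatic ring altogether, so a weaker inhibitor is expected, although a single step gives only a rough guide. The expected change is a 2.3-fold higher number from compound 2 to compound 3 (0.37 log units; beyond the scatter). For compound 3 the estimated value is 30000 nM, with an expected range from 11000 nM to 80000 nM.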

Compound 3, half-maximal inhibitory concentration: > 50000 nM
Compound 3 gave a limit, no number (the forecaster's own chance of this, stated with the estimate: 40%); middle value at least 1.6-fold (0.22 log units) away from the limit.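

In this assay, chloro in place of 3-methylphenoxy gives an at least 3.9-fold higher number from compound 2 to compound 3 (0.59 log units; beyond the scatter), so replacing the ring-bearing group with a single atom does not keep the measurable activity of compound 2. For the compounds shown here, the earlier pair compared only two aromatic groups on the oxygen, whereas this change removes both the oxygen and the ring, and of the three groups at this position only 3-methylphenoxy yields a true number. The step between compound 1 and compound 3 cannot be read, since both results are limits and chloro and 4-iodophenoxy cannot be ranked against each other: the limit of > 50000 nM in this assay, at which 2 of the 3 values shown sit.

As far as these compounds go, it remains open whether the ring, the oxygen or the methyl group matters most for the activity of compound 2. Plain phenoxy, or an amine linking the phenyl ring to this carbon, would help to separate these parts.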